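This account rests on a few compounds, and the source may have more. Where it says the series, first, only, none or still open, it means among the compounds named here.

Measured compounds:
- compound 1 `Cc1cc(/C=C/C#N)cc(C)c1Oc1nc(Nc2ccc(N3CCCC(N)C3)cc2)nc2ccsc12`: 3820 nM
- compound 2 `Cc1cc(/C=C/C#N)cc(C)c1Oc1nc(Nc2ccc(CN3CCN(S(C)(=O)=O)CC3)cc2)nc2sccc12`: 131000 nM

In an ADME assay on MT4 cells (Homo sapiens) for cytotoxicity, read by MTT assay, with a stated time of 5 days (on this read-out lower numbers stand for higher toxicity in this test and higher numbers for lower toxicity in this test), compound 1 gives 3820 nM, the lowest of the two numbers recorded. Its nearest neighbour is compound 2, which in this assay gives 131000 nM, a much higher number, well beyond the scatter of the test. Compound 2 differs from compound 1 in more than one place, so the two values are set side by side without a single change being credited with the gap.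

The step of interest leads from compound 1 to compound 3 `Cc1cc(/C=C/C#N)cc(C)c1Oc1nc(Nc2ccc(N3CCCC(NS(C)(=O)=O)C3)cc2)nc2ccsc12`. The change is methylsulfonyl in place of hydrogen on an amine nitrogen, turning the 3-aminopiperidin-1-yl group into a 3-(methanesulfonamido)piperidin-1-yl group. No step between two measured compounds matches this change, so the expectation rests only on the two numbers shown. Because compound 2, which carries a methylsulfonyl on a ring nitrogen, gives 131000 nM, compound 3 is expected to move towards higher numbers in this assay, a step of a 3.9-fold higher number from compound 1 to compound 3 (0.59 log units; beyond the scatter). Compound 3 is therefore estimated at 15000 nM, with a range from 4000 nM to 60000 nM.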

Compound 3, half-maximal cytotoxic concentration: > 217000 nM
Compound 3 ended at the assay's limit (the forecaster's own chance of this, stated with the estimate: 15%); middle value at least 14-fold (1.16 log units) from the limit.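

In this assay, methylsulfonyl in place of hydrogen on an amine nitrogen, which turns the 3-aminopiperidin-1-yl group into a 3-(methanesulfonamido)piperidin-1-yl group, gives an at least 56-fold higher number from compound 1 to compound 3 (1.75 log units; beyond the scatter). The reading for compound 3, > 217000 nM, is a limit of the assay and not a number: the limit of > 217000 nM in this assay, at which 1 of the 3 values shown sits. Going by these compounds alone, until this step, the only comparison available was between two compounds differing in more than one place, whereas this one shows that a single change on this nitrogen is enough to carry the read-out from a value well inside the range of the test to its limit, on the side of lower toxicity in this test.

The compounds shown leave open whether this step belongs to methylsulfonyl itself or would also follow from an acetyl or a methyl group on the same nitrogen, or from a hydroxyl group in place of the amino group. They also leave open how far the step extends beyond this position, since compound 2 carries its methylsulfonyl on a different ring nitrogen and differs from compound 3 in more than one place.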